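Swapping carboxy for bromo on a mid-ranked compound

The source may hold more compounds than are shown below. What is called first, only, known or untested is meant among the compounds shown, and "the series" means these compounds.

In a functional assay on HUVEC cells (Homo sapiens) for inhibition, using NADPH, with a stated time of 2 h (on this read-out higher numbers stand for weaker inhibition and lower numbers for stronger inhibition), compound 1 (`Cc1c(COc2cccc(OCC3CCOCC3)c2)[nH]c2ccc(C(=O)O)cc2c1=O`) gives 400 nM as its reading, the middle of three numbers. Compound 2 (`CCCCCCCCCc1[nH]c2ccccc2c(=O)c1C`) reads lower, with 5.6 nM as its number, and compound 3 (`Cc1c(COCCCCO)[nH]c2ccccc2c1=O`) reads higher, with 2600 nM as its number. Compound 4 (`Cc1c(COc2cccc(OCC3CCOCC3)c2)[nH]c2ccc(Br)cc2c1=O`) has bromo in place of carboxy on an aromatic carbon. Among the measured compounds shown here, neither compound 2 nor compound 3 carries the carboxy group, yet their readings lie far apart, and no measured pair isolates this swap. A moderate step toward stronger inhibition in this assay is still expected, beyond the scatter. The expected change is an 8.0-fold lower number from compound 1 to compound 4 (0.90 log units; beyond the scatter) on this estimate. For compound 4 the estimated value is 50 nM with an expected range of 10 nM to 250 nM as the likely span.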

Compound 4, half-maximal inhibitory concentration in the HUVEC assay: 23 nM
Beside the measured number, compound 4's estimate is 2.2-fold (0.34 log units) above it; the range from low to high includes it.
By their numbers in the HUVEC assay, from the lowest: compound 2; then compound 4; then compound 1; then compound 3.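

In the HUVEC assay, this aromatic carbon proves sensitive to what it carries, with bromo in place of carboxy giving a 17-fold lower number from compound 1 to compound 4 (1.24 log units; beyond the scatter). In a physicochemical assay for solubility, at pH 6.8 (on this read-out higher numbers stand for higher solubility and lower numbers for lower solubility), compound 1 reads >= 100000 nM, a limit of the assay, not an exact number: the limit of >= 100000 nM in the physicochemical assay, at which 1 of the 2 values shown sits. In the physicochemical assay, compound 4 reads < 1000 nM, also a limit, which still places its solubility far lower: the limit of < 1000 nM in the physicochemical assay, at which 1 of the 2 values shown sits.

From the compounds shown here alone, whether the stronger inhibition comes from adding bromo or from losing carboxy stays open. So does whether chloro, an amine or an amide here could combine strong inhibition with good solubility.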